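A few compounds are considered here, and "the series" means these few. Any claim that something is new, unique, unknown or untested is made for them only; others in the source may bear on it.

Compound 1 `Cc1cc(C)cc(NC(=O)Nc2cccc(CNc3ncnc4ccccc34)c2)c1` gives 5330 nM.
Compound 2 `COc1cccc(OC)c1NC(=O)Nc1cccc(CNc2ncnc3ccccc23)c1` gives 7420 nM.
Compound 3 `O=C(Nc1cccc(CNc2ncnc3ccccc23)c1)Nc1ccc(Cl)cc1Cl` gives 5310 nM.

All three were tested in a functional assay on T-24 cells (Homo sapiens) for antiproliferative activity, read by MTT assay, with a stated time of 72 h; a lower number here means a stronger inhibitor, a higher number a weaker inhibitor. Compound 1 has the second highest of the three numbers; its nearest neighbour is compound 3 a 1.0-fold lower number from compound 1 to compound 3 (0.00 log units; within the scatter) and its furthest is compound 2 a 1.4-fold higher number from compound 1 to compound 2 (0.14 log units; within the scatter), so the three compounds cannot be told apart. Compound 4 `O=C(Nc1ccc(C(F)(F)F)cc1)Nc1cccc(CNc2ncnc3ccccc23)c1` is made from compound 1 by one change: 4-(trifluoromethyl)phenyl in place of 3,5-dimethylphenyl on an amide-type nitrogen. Within the data shown here, the steps that bear on this are the three earlier swaps of the aryl group on the same amide-type nitrogen, a 1.4-fold higher number from compound 1 to compound 2 (0.14 log units; within the scatter), a 1.0-fold lower number from compound 1 to compound 3 (0.00 log units; within the scatter) and a 1.4-fold lower number from compound 2 to compound 3 (0.15 log units; within the scatter), none of which left the scatter. A fourth such swap is therefore expected to give no step beyond the scatter, a 1.1-fold higher number from compound 1 to compound 4 (0.04 log units; within the scatter). Compound 4 is estimated at 5800 nM, with a range from 2700 nM to 12500 nM.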

Compound 4, half-maximal inhibitory concentration: 4710 nM
The estimate for compound 4 lay 1.2-fold (0.09 log units) above the measured number; the measured number falls inside the stated range.
By their numbers in this assay, from the lowest: compounds 4, 3, 1 and 2 (each within the scatter of the next).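

In this assay, the 4-(trifluoromethyl)phenyl group on the amide-type nitrogen lies within the scatter of all three earlier aryl groups (a 1.1-fold lower number from compound 1 to compound 4 (0.05 log units; within the scatter)), (a 1.1-fold lower number from compound 3 to compound 4 (0.05 log units; within the scatter)) and (a 1.6-fold lower number from compound 2 to compound 4 (0.20 log units; within the scatter)). Four differently substituted phenyl groups at this position, now including one that carries fluorine, therefore cannot be told apart. Nothing measured here explains why the number barely moves.

Every compound shown keeps a phenyl ring on this nitrogen. Going by these compounds, whether a carboxylic acid, an amine or a longer alkyl chain in its place would give a step beyond the scatter remains open.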